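A few compounds are considered here, and "the series" means these few. Any claim that something is new, unique, unknown or untested is made for them only; others in the source may bear on it.

The measured compounds:

Compound 1, `Cc1cc(OCCCCOc2ccc(C(=O)CC3CCCC3)c(O)c2C)ccc1C(=O)O`: > 10000 nM
Compound 2, `CC(=O)c1ccc(OCCCCOc2cccc(C(=O)O)c2C)c(C)c1O`: "not determined" (no result reported)
Compound 3, `Cc1c(OCCCCOc2ccc(C(=O)O)cc2)ccc(C(=O)CC(C)C)c1C`: "not determined" (no result reported)

The three compounds were tested in an assay on HEK293 cells for positive allosteric modulation of metabotropic glutamate receptor 3 (Rattus norvegicus), read by thallium flux, with a stated time of 2.5 min; a higher number here means that more compound is needed for the effect, a lower number that less compound is needed. For compound 1 the result is a limit of the assay and not a number, > 10000 nM. For compound 2 the entry is "not determined" (no result reported), and for compound 3 it is likewise "not determined" (no result reported), so neither gives a number to compare against. Among the three entries only compound 1 carries any result, and that result is the limit of > 10000 nM in this assay, at which 1 of the 3 values shown sits.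

Compound 4, `Cc1cc(C(=O)O)ccc1OCCCCOc1ccc(C(=O)CC2CCCC2)c(O)c1C`, has not yet been measured in this assay. It differs from compound 1 in one place: 4-carboxy-2-methylphenyl in place of 4-carboxy-3-methylphenyl on an oxygen on a saturated carbon. The two share all their atoms and differ only in how they are joined.

Among the measured compounds shown here, no step between two measured compounds is available to set a scale. Because compound 1 sits at > 10000 nM, the most likely outcome is that compound 4 also returns only a limit. The expected step that the limit leaves unreadable from compound 1 to compound 4 is estimated as none beyond the usual scatter. Compound 4 is therefore expected at about 15000 nM, with a range from 5000 nM to 50000 nM.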

Compound 4, half-maximal effective concentration: > 10000 nM
Compound 4 gave a limit, no number; the forecaster's own chance of this, stated with the estimate: 75%; the middle value lies beyond the limit too.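

Neither compound 1 nor compound 4 gives a number in this assay, so no step between them can be read: the limit of > 10000 nM in this assay, at which 2 of the 4 values shown sit.

The compounds shown leave open whether 4-carboxy-2-methylphenyl in place of 4-carboxy-3-methylphenyl on an oxygen on a saturated carbon changes how much compound is needed for the effect.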